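The source may hold more compounds than are shown below. What is called first, only, known or untested is meant among the compounds shown, and "the series" means these compounds.

Of the compounds shown here, three have so far been tested in a functional assay on TK-10 cells (Homo sapiens) for cytotoxicity, read by sulforhodamine B assay, with a stated time of 48 h; a higher number here means that more compound is tolerated, a lower number that less compound is tolerated. Compound 1 `Nc1nc(Cl)c2ncn(Cc3ccccc3CCl)c2n1` gives 75900 nM, the highest of the three numbers. Compound 2 `ClCc1ccc(Cn2cnc3c(Cl)nc(Cl)nc32)cc1` gives 44700 nM, a number within the scatter of compound 1, so the two cannot be told apart. Compound 3 `Nc1nc(Cl)c2ncn(Cc3cccc(CCl)c3)c2n1` gives 27500 nM, a lower number beyond the scatter, so compound 3 is tolerated less well than compound 1. Compound 4 `ClCc1ccccc1Cn1cnc2c(Cl)ncnc21` has not yet been measured in this assay. It differs from compound 1 in one place: hydrogen in place of amino on an aromatic carbon. Within the data shown here, no measured pair shows this change, so its effect is unknown. The step of a 1.4-fold lower number from compound 1 to compound 4 (0.14 log units; within the scatter) is expected to be small, within the scatter. Compound 4 is estimated at 55000 nM, with a range from 25000 nM to 130000 nM.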

Compound 4, concentration lethal to 50% of the cells: 95500 nM
For compound 4 the middle estimate is 1.7-fold (0.24 log units) below the measured one; the measured number falls inside the stated range.
By their numbers in this assay, from the lowest: compounds 3, 2, 1 and 4 (each within the scatter of the next, the first and the last beyond it).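

In this assay the first pair differing in one place gives a 1.3-fold higher number from compound 1 to compound 4 (0.10 log units; within the scatter) when hydrogen replaces amino on the aromatic carbon between two ring nitrogen atoms. Amino at this position can therefore be removed, with its hydrogen-bond donor and acceptor, without a difference this assay can distinguish. Nothing available explains this result. This single pair cannot show whether the same holds in the other compounds shown. It also leaves open whether a methylamino, hydroxyl or methoxy group at this position would give a number beyond the scatter.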